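The source may hold more compounds than are shown below. What is called first, only, known or untested is meant among the compounds shown, and "the series" means these compounds.

In a functional assay on HeLa cells (Homo sapiens) for inhibition, read by MTT assay, with a stated time of 72 h (on this read-out lower numbers stand for stronger inhibition and higher numbers for weaker inhibition), compound 1 `Fc1ccc(-c2nnc(SCCCN3CCN(c4nc5ccccc5o4)CC3)o2)cc1` gives 196000 nM and compound 2 `Cc1ccc(-c2nnc(SCCCN3CCN(c4nc5ccccc5s4)CC3)o2)cc1` gives 179000 nM so the two stand within the usual scatter of each other. The difference hydroxy in place of methyl on an aromatic carbon leads from compound 2 to compound 3 `Oc1ccc(-c2nnc(SCCCN3CCN(c4nc5ccccc5s4)CC3)o2)cc1` with hydroxy in place of methyl on an aromatic carbon. For the measured compounds named here, no measured pair shows this change, so only a modest step towards a lower number is expected in this assay and little beyond the scatter. An estimated 1.5-fold lower number from compound 2 to compound 3 (0.17 log units; within the scatter) would fit that expectation. Compound 3 is estimated at 120000 nM with an expected range from 45000 nM to 260000 nM for now.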

Compound 3, half-maximal inhibitory concentration: 139000 nM
The estimate for compound 3 lay 1.2-fold (0.06 log units) below the measured number; measured number inside the range.
By their numbers in this assay, from the lowest: compounds 3, 2 and 1 (each within the scatter of the next).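

In this assay the change from 4-methylphenyl to 4-hydroxyphenyl gives a 1.3-fold lower number from compound 2 to compound 3 (0.11 log units; within the scatter) and is the only single-place step shown. This position on the six-membered aromatic ring therefore accepts a hydroxy, with its hydrogen-bond donor and acceptor, while the two compounds remain within the scatter of each other. No available measurement explains this result.

From the compounds shown here alone, whether an amine or a carboxylic acid at this position would give a step beyond the scatter remains open. The steps shown also say nothing about a longer chain elsewhere in the core of compound 2.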